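The source may report more compounds than this note shows. Statements on the series, on what has been measured and on what is new or still open speak of the compounds shown alone.

Working notes on the series. In a functional assay on A549 cells (Homo sapiens) for antiproliferative activity, read by MTT assay, with a stated time of 48 h (a lower number here means a stronger inhibitor, a higher number a weaker inhibitor), compound 1 (`Cc1ccc(/C=C/C(=O)Nc2nnc(-c3ccc(Cl)cc3)s2)cc1`) gives 1.25 ug/mL and compound 2 (`O=C(/C=C/c1ccc(F)cc1)Nc1nnc(-c2ccccc2)s1`) gives 1.82 ug/mL. Among the measured compounds shown here, these two values lie within the scatter of each other, so compound 2 stands level with compound 1 on the only two numbers available. Compound 3 (`O=C(/C=C/c1ccc(F)cc1)Nc1nnc(-c2ccc(Cl)cc2)s1`) differs from compound 2 by chloro in place of hydrogen on an aromatic carbon, para to a large group, so that phenyl becomes 4-chlorophenyl. For the measured compounds named here, no measured pair isolates this change. Going by the values given here, the only guide is compound 1, which also carries a 4-chlorophenyl and gives 1.25 ug/mL. No shift beyond the scatter is therefore expected in this assay, at most a small move towards a lower number. The expected step is a 1.3-fold lower number from compound 2 to compound 3 (0.11 log units; within the scatter). The estimate for compound 3 is 1.4 ug/mL, with an expected range from 0.7 ug/mL to 2.8 ug/mL.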

Compound 3, half-maximal inhibitory concentration: 2.06 ug/mL
For compound 3 the middle estimate is 1.5-fold (0.17 log units) below the measured one, and the stated range covers the measured number.
By their numbers in this assay, from the lowest: compounds 1, 2 and 3 (each within the scatter of the next).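

In this assay, chloro in place of hydrogen on an aromatic carbon, para to a large group, now has a direct reading: a 1.1-fold higher number from compound 2 to compound 3 (0.05 log units; within the scatter). Phenyl and 4-chlorophenyl therefore stand level when the fluoro group of compound 2 is kept, so this change does not separate the two compounds in this assay. Fluoro in place of methyl on an aromatic carbon gives a 1.6-fold higher number from compound 1 to compound 3 (0.22 log units; within the scatter), so that change also leaves its pair level, and no measurement offers an explanation for either reading.

From the compounds shown here alone, whether any group at the chloro position can move the number beyond the scatter remains open, for example an amine or a carboxylic acid. Also open, going by these compounds, is whether a longer chain in place of the fluoro or methyl group would do so.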